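Swapping a Protected Pyrrolidine for a Free Piperidine

The source may report more compounds than this note shows. Statements on the series, on what has been measured and on what is new or still open speak of the compounds shown alone.

Compound 1 `O=C(c1ccccc1)N1CCC(NS(=O)(=O)c2cc(S(=O)(=O)c3ccccc3)ccc2C(F)(F)F)CC1` gives 250 nM in an assay on U2OS cells for inhibition of secreted frizzled-related protein 1 (Homo sapiens), read by a luciferase reporter, with a stated time of 18 h; a higher number here means that more compound is needed for the effect, a lower number that less compound is needed.
Compound 2 `O=C(c1ccc(C(F)(F)F)cc1)N1CCC(NS(=O)(=O)c2cc(S(=O)(=O)c3ccccc3)ccc2C(F)(F)F)CC1` gives 970 nM in this assay.
Compound 3 `CC(C)(C)OC(=O)N1CC[C@H](C(=O)N2CCC(NS(=O)(=O)c3cc(S(=O)(=O)c4ccccc4)ccc3C(F)(F)F)CC2)C1` gives 150 nM in this assay.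

All three share the same core and differ only in the group attached to the carbonyl carbon of the amide. Compound 3 has the lowest number of the three, but its step from compound 1 is a 1.7-fold lower number from compound 1 to compound 3 (0.22 log units; within the scatter), so those two cannot be told apart, while a 6.5-fold lower number from compound 2 to compound 3 (0.81 log units; beyond the scatter) is a real gain. The step of a 3.9-fold higher number from compound 1 to compound 2 (0.59 log units; beyond the scatter) shows that adding a trifluoromethyl to the phenyl on that carbonyl costs potency.

Compound 4 `O=C(CC1CCNCC1)N1CCC(NS(=O)(=O)c2cc(S(=O)(=O)c3ccccc3)ccc2C(F)(F)F)CC1` carries the change ((piperidin-4-yl)methyl in place of 1-(tert-butoxycarbonyl)pyrrolidin-3-yl on a carbonyl carbon). Among the measured compounds shown here, neither measured step matches this: the only steps at the carbonyl carbon trade one carbonyl substituent for another without removing a tert-butoxycarbonyl or introducing a free ring nitrogen bearing a hydrogen. The steps seen here are modest at most, and compound 1 and compound 3 show that quite different groups at this position can give similar numbers. With no guiding data for a free piperidine, the expected step is a 2.0-fold higher number from compound 3 to compound 4 (0.30 log units; within the scatter), a small loss wide enough to span either direction. Compound 4 is therefore estimated at 300 nM in this assay, with a range from 80 nM to 1200 nM.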

Compound 4, half-maximal effective concentration: 210 nM
Beside the measured number, compound 4's estimate is 1.4-fold (0.15 log units) above it; measured number inside the range.
By their numbers in this assay, from the lowest: compounds 3, 4 and 1 (each within the scatter of the next); then compound 2.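

In this assay, the (piperidin-4-yl)methyl group can replace the 1-(tert-butoxycarbonyl)pyrrolidin-3-yl group with no readable change, giving a 1.4-fold higher number from compound 3 to compound 4 (0.15 log units; within the scatter), even though it has fewer heavy atoms, a six-membered rather than a five-membered ring, and a hydrogen-bond donor that the departing group lacks. With a 1.2-fold lower number from compound 1 to compound 4 (0.08 log units; within the scatter) also inside the scatter, a phenyl, a protected pyrrolidine and a free piperidine cannot be told apart on this carbonyl carbon, whereas the 4-(trifluoromethyl)phenyl of compound 2 stands apart from the new group, with a 4.6-fold lower number from compound 2 to compound 4 (0.66 log units; beyond the scatter) as the step. Nothing available explains why such different groups give numbers this close.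

Compound 3 and compound 4 differ in several features at once, so the free ring nitrogen cannot be judged on its own, and an acetyl or tert-butoxycarbonyl group on the piperidine nitrogen would address that directly. A cyclohexylmethyl group, with carbon in place of that nitrogen, would show whether the ring nitrogen matters at all at this position.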